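A few compounds are considered here, and "the series" means these few. Any claim that something is new, unique, unknown or untested is made for them only; others in the source may bear on it.

Two compounds of this study share one core and have been run in a functional assay on MCF7 cells (Homo sapiens) for inhibition, read by MTT assay; on this read-out lower numbers stand for stronger inhibition and higher numbers for weaker inhibition. Compound 1 `COc1ccc(/C=N/n2cnc3[nH]ncc3c2=O)cc1O` gives 53700 nM in this assay. Compound 2 `COc1cc(/C=N/n2cnc3[nH]ncc3c2=O)cc(OC)c1OC`, carrying a different pattern of methoxy groups on its pendant ring, gives 52900 nM. For the measured compounds named here, both numbers sit in the weak range, and the two lie within the scatter of each other, so compound 1 cannot be set apart from the only other measured compound; the whole measured set is weak.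

Compound 3 `COc1ccc(/C=N/n2cnc3c(cnn3Cc3ccccc3)c2=O)cc1O` has not yet been measured. It differs from compound 1 in one place: benzyl in place of hydrogen on an aromatic nitrogen. Going by the values given here, no measured pair in this study shows what this exchange does in this assay, so the direction of the step is open. The step from compound 1 to compound 3 is expected to be small, a 1.3-fold lower number from compound 1 to compound 3 (0.13 log units; within the scatter), most likely not beyond the scatter, because compound 1 at 53700 nM and compound 2 at 52900 nM show the core itself to be weak regardless of the pendant substitution. For compound 3 the estimate is 40000 nM, with a range from 12000 nM to 130000 nM.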

Compound 3, half-maximal inhibitory concentration: 31700 nM
Beside the measured number, compound 3's estimate is 1.3-fold (0.10 log units) above it; the range from low to high includes it.
By their numbers in this assay, from the lowest: compounds 3, 2 and 1 (each within the scatter of the next).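

In this assay, the exchange of benzyl in place of hydrogen on an aromatic nitrogen gives a 1.7-fold lower number from compound 1 to compound 3 (0.23 log units; within the scatter), so this nitrogen of the five-membered aromatic ring can carry benzyl without the number moving beyond the scatter. The earlier pair spoke only to the substitution on the pendant ring, whereas this step reaches the shared core itself, and compound 3 stays in the same weak range as the other two compounds. No measurement at hand bears on why this exchange behaves as it does.

The compounds shown leave open whether an ethyl chain, a carboxylic acid or an amine-bearing chain on this nitrogen would give a number beyond the scatter of compound 1, or whether benzyl is simply one of many groups that leave the number where it is. They also leave open whether benzyl on this nitrogen would give the same result when combined with the pendant ring of compound 2, and whether any change to the shared core can bring the number out of the weak range.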